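The source may report more compounds than this note shows. Statements on the series, on what has been measured and on what is new or still open speak of the compounds shown alone.

Compound 1 `O=C(Nc1ccc2[nH]cc(C3CCN(CCCCCCCCCN4CCC(c5c[nH]c6ccc(NC(=O)c7ccc(F)cc7)cc56)CC4)CC3)c2c1)c1ccc(F)cc1` gives 1 nM in an assay on CHO-K1 cells for displacement of a labelled ligand from 5-hydroxytryptamine receptor 1D (Homo sapiens), read by scintillation counting; on this read-out higher numbers stand for weaker inhibition and lower numbers for stronger inhibition.
Compound 2 `CCCCCCCCN1CCC(c2c[nH]c3ccc(NC(=O)c4ccc(F)cc4)cc23)CC1` gives > 1000 nM, which is a limit of the assay and not a number.
Compound 3 `O=C(Nc1ccc2[nH]cc(C3CCN(CCN4CCCCC4)CC3)c2c1)c1ccc(F)cc1` gives > 1000 nM, again a limit of the assay and not a number.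

Compound 3 therefore stands at the limit of this assay, and a second value in this set, that of compound 2, sits at the same limit (the limit of > 1000 nM in this assay, at which 2 of the 3 values shown sit). Only compound 1 returns an actual number. For the measured compounds named here, the one step between measured compounds that differ in a single place, a step that the two limits leave unreadable from compound 2 to compound 3, runs from one limit to the other and so has no readable size.

Compound 4 `CN(C)CCCN1CCC(c2c[nH]c3ccc(NC(=O)c4ccc(F)cc4)cc23)CC1` is the not yet measured compound. It differs from compound 3 by (dimethylamino)methyl in place of piperidin-1-yl on a saturated chain carbon, two bonds along the chain from an amine nitrogen in a ring. Going by the values given here, the only measured step that bears on a change at this place, from compound 2 to compound 3, gives no number to carry over, so there is no basis for expecting a readable step in this assay in either direction. Compound 4 is expected to give 2000 nM, with a range from 500 nM to 10000 nM, and most likely to be reported again only as a limit. The expected step that the limit leaves unreadable from compound 3 to compound 4 is an estimate and is not expected to be readable.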

Compound 4, inhibition constant: > 1000 nM
Compound 4: a limit, no number (the forecaster's own chance of this, stated with the estimate: 70%); the middle value lies beyond the limit too.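

Neither the step from compound 3 to compound 4 nor the step from compound 2 to compound 4 can be read, because all three compounds return only a limit and not a number: the limit of > 1000 nM in this assay, at which 3 of the 4 values shown sit.

On these data alone, what stays open is how strongly compound 2, compound 3 and compound 4 each inhibit in this assay, and so whether the changes among them make any difference.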